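Swapping the Aryl Substituent on a Shared Core

A few compounds are considered here, and "the series" means these few. Any claim that something is new, unique, unknown or untested is made for them only; others in the source may bear on it.

Of the compounds shown here, three built on one shared core have been measured in a functional assay on MDA-MB-231 cells (Homo sapiens) for antiproliferative activity, read by MTT assay, with a stated time of 48 h; a higher number here means a weaker inhibitor, a lower number a stronger inhibitor. Compound 1 `CCOC(=O)/C(=C/c1ccccc1)CN1C(=O)[C@@H](OC)[C@H]1c1ccc(Cl)cc1` gives 11100 nM, compound 2 `COC(=O)/C(=C/c1ccccc1)CN1C(=O)[C@@H](OC)[C@H]1c1ccc(Cl)cc1` gives 15600 nM, and compound 3 `COc1ccc(OC)c([C@@H]2[C@H](OC)C(=O)N2C/C(C#N)=C/c2ccccc2)c1` gives 23400 nM. Going by the values given here, the only pair that differs in a single place is compound 1 and compound 2, where hydrogen replaces methyl on a saturated chain carbon bound to an oxygen next to a carbonyl group; that step, a 1.4-fold higher number from compound 1 to compound 2 (0.15 log units; within the scatter), lies within the scatter. Compound 2 stands second highest of the three numbers, with compound 1 its nearest neighbour and compound 3 its furthest, but both gaps are within the scatter, so the three cannot be put in order.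

Compound 4 `COC(=O)/C(=C/c1ccccc1)CN1C(=O)[C@@H](OC)[C@H]1c1cccc(F)c1` has not yet been measured. It differs from compound 2 in one place: 3-fluorophenyl in place of 4-chlorophenyl on a saturated ring carbon. Among the compounds with values here, no measured pair shows this exchange, and compound 3 differs from compound 2 in more than one place, so its value offers no direct guidance. With nothing bearing on the change, the expected step is none beyond the scatter, a 1.2-fold higher number from compound 2 to compound 4 (0.06 log units; within the scatter). Compound 4 is therefore estimated at 18000 nM, within a range from 7000 nM to 45000 nM.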

Compound 4, half-maximal inhibitory concentration: 34400 nM
Compound 4: middle estimate off by 1.9-fold (0.28 log units), on the low side, and the stated range covers the measured number.
By their numbers in this assay, from the lowest: compounds 1, 2, 3 and 4 (each within the scatter of the next, the first and the last beyond it).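

In this assay, replacing 4-chlorophenyl with 3-fluorophenyl on the saturated ring carbon, next to the ring nitrogen, gives a 2.2-fold higher number from compound 2 to compound 4 (0.34 log units; beyond the scatter), the only single-place step shown so far to pass beyond the scatter, though only modestly. Going by these compounds alone, the only earlier single-place step, at the other end of the molecule, was a 1.4-fold higher number from compound 1 to compound 2 (0.15 log units; within the scatter), which stayed within the scatter, so this aryl position is the first place where a single exchange can be seen to move the number, and the move is towards a weaker inhibitor. The exchange alters both the halogen and where it sits on the phenyl ring, and nothing available explains the shift or assigns it to either alteration.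

The compounds shown leave open whether a plain phenyl or a bromophenyl group on this carbon would fall nearer compound 2 or compound 4, and so whether the halogen or its location carries the step. They also leave open whether the same exchange would give a similar step with the ethyl ester of compound 1 or the nitrile of compound 3 in place of the methyl ester.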